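Methoxy for ethyl on the chain of compound 3

The source may report more compounds than this note shows. Statements on the series, on what has been measured and on what is new or still open speak of the compounds shown alone.

In a physicochemical assay for solubility, in phosphate buffer, measured as kinetic solubility, at pH 7.4, tested at 250 uM (a lower number here means a less soluble compound, a higher number a more soluble compound), compound 3 (`CCCCCCCCNc1ccc(C(=O)O)cc1S(=O)(=O)N(C)C`) gives 52000 nM and stands lowest of the three measured numbers. Compound 1 (`CCCCCCNc1ccc(C(=O)O)cc1S(N)(=O)=O`) gives 238000 nM and compound 2 (`CCCCCCNc1ccc(C(=O)O)cc1S(=O)(=O)NC`) gives 247000 nM and both lie beyond the scatter from compound 3. The next structure is compound 4 (`COCCCCCCNc1ccc(C(=O)O)cc1S(=O)(=O)N(C)C`). The change is methoxy in place of ethyl on a saturated chain carbon, six bonds along the chain from a nitrogen on an aromatic ring with methoxy in place of ethyl on a saturated chain carbon, six bonds along the chain from a nitrogen on an aromatic ring.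

Within the data shown here, the only measured step is a 1.0-fold higher number from compound 1 to compound 2 (0.02 log units; within the scatter) for methyl in place of hydrogen on a sulfonamide nitrogen. It lies within the scatter and concerns a different group, so it says little here. Among the measured compounds shown here, no measured step covers the chain change itself. Compound 3 differs from compound 1 and compound 2 in more than one place, so those gaps are not clean steps. Even so, compound 2 at 247000 nM shows that the shared core can reach much higher numbers, and a move in that direction is expected. The estimated step is a 2.5-fold higher number from compound 3 to compound 4 (0.40 log units; beyond the scatter) and it remains uncertain. For compound 4 the estimate is 130000 nM with an expected range from 65000 nM to 250000 nM in this assay as the measure.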

Compound 4, solubility: > 250000 nM
Compound 4 gave a limit, no number; the forecaster's own chance of this, stated with the estimate: 10%; middle value at least 1.9-fold (0.28 log units) from the limit.
By their numbers in this assay, from the lowest: compound 3; then compounds 1 and 2 (each within the scatter of the next). At a limit, above all of these: compound 4.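

In this assay compound 4 gives > 250000 nM, which is a limit of the assay and not a number. Among these compounds, the exchange of methoxy for ethyl on a saturated chain carbon, six bonds along the chain from a nitrogen on an aromatic ring, gives an at least 4.8-fold higher number from compound 3 to compound 4 (0.68 log units; beyond the scatter), so this place on the chain can move the read-out beyond the scatter, whereas the only earlier step, on a sulfonamide nitrogen, gave a 1.0-fold higher number from compound 1 to compound 2 (0.02 log units; within the scatter). From the compounds shown here alone, the step from compound 3 can be read only as a lower bound, and its full size stays unknown because the reading for compound 4 stops at the ceiling of the assay: the limit of > 250000 nM in this assay, at which 1 of the 4 values shown sits.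

Compound 4 is the only compound shown with methoxy in this place, so it remains open whether the step carries over to a shorter chain, a longer chain or a different sulfonamide from that of compound 3. Going by these compounds, it also remains open how a hydroxyl, an amine or a carboxylic acid in the same place would compare, and any such comparison in this assay would need a compound whose reading falls under the limit.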